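Pyrazole ureas in the writhing test: swapping the aryl amide

This account rests on a few compounds, and the source may have more. Where it says the series, first, only, none or still open, it means among the compounds named here.

Two members of the series have numbers. In a functional assay on the whole organism (strain Swiss albino) for inhibition, with Mus musculus as the target, in the writhing test, with a stated time of 30 min, at a dose of 100 mg/kg (on this read-out higher numbers stand for more inhibition at the one dose given (going by the name of the read-out) and lower numbers for less inhibition), compound 1 `CCN1CCc2c(c(C)nn2C(=O)Nc2ccc(F)cc2F)C1` gives 76.3%. Compound 2 `CCN1CCc2c(c(C(C)(C)C)nn2C(=O)Nc2cc(C)ccc2C)C1` carries a tert-butyl group on the core where compound 1 carries methyl, and a different aryl group on the amide nitrogen; in this assay compound 2 gives 63.1%, the lower of the two numbers, with compound 1 standing higher by a gap that is beyond the usual scatter. Since compound 1 and compound 2 differ in two places at once, the two values show only their combined outcome and nothing about either change on its own.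

Compound 3 `CCN1CCc2c(c(C(C)(C)C)nn2C(=O)Nc2ccc(F)cc2F)C1` has not been measured in this assay. It differs from compound 2 in one place: 2,4-difluorophenyl in place of 2,5-dimethylphenyl on an amide-type nitrogen. Compound 3 thus shares its aryl group with compound 1 and its tert-butyl group with compound 2. The expected step from compound 2 to compound 3 in this assay is upward and modest, a number 6.9 percentage points higher from compound 2 to compound 3 (within the scatter), since compound 1 with the same aryl group gives 76.3%. For compound 3 the estimate in this assay is 70%, with a range from 55% to 85%.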

Compound 3, a percentage reported as inhibition, in the whole organism at one dose (the size of the read-out at that dose, not a potency): 71.9%
Compound 3: the middle estimate sits 1.9 percentage points below what was measured; the measured number falls inside the stated range.
By their numbers in this assay, from the lowest: compounds 2, 3 and 1 (each within the scatter of the next, the first and the last beyond it).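

In this assay the aryl swap on the amide-type nitrogen can now be read on its own: with tert-butyl held on the core, 2,4-difluorophenyl in place of 2,5-dimethylphenyl gives a number 8.8 percentage points higher from compound 2 to compound 3 (within the scatter). The change on the core can be read on its own as well: with 2,4-difluorophenyl held on the amide-type nitrogen, tert-butyl in place of methyl on an aromatic carbon gives a number 4.4 percentage points lower from compound 1 to compound 3 (within the scatter), so neither single change separates from the usual scatter in these compounds. Nothing at hand bears on the cause of either step.

The shown compounds cover only methyl and tert-butyl on that aromatic carbon and only two aryl groups on the amide-type nitrogen, so it remains open whether an ethyl or cyclopropyl group on the core, or an unsubstituted phenyl or pyridyl ring on the nitrogen, would give a step beyond the scatter. The read-out is also a single-dose percentage, which leaves open how these compounds would relate to one another at other doses.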